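Removing the Amino Group of Compound 1

The source may hold more compounds than are shown below. What is called first, only, known or untested is meant among the compounds shown, and "the series" means these compounds.

Compound 1 `CNc1cc(NC)c2ccn(S(=O)(=O)c3ccc(N)cc3)c2c1` gives 1.9 nM in an assay on HEK293 cells for displacement of a labelled ligand from 5-hydroxytryptamine receptor 6 (Homo sapiens) (on this read-out lower numbers stand for stronger inhibition and higher numbers for weaker inhibition), the lowest of the two numbers measured. Compound 2 `CNc1cccc2c1ccn2S(=O)(=O)c1ccc(N)cc1` gives 21 nM, and the step of an 11-fold higher number from compound 1 to compound 2 (1.04 log units; beyond the scatter) is large. Compound 3 `CNc1cc(NC)c2ccn(S(=O)(=O)c3ccccc3)c2c1` differs from compound 1 at another place: hydrogen in place of amino on an aromatic carbon, that is, 4-aminophenyl to phenyl. For the measured compounds named here, the only measured step concerns a methylamino on the shared core, not the phenyl, so it is no direct guide here. Compound 3 is expected to give 5 nM, with a range of 1.5 nM to 20 nM. That amounts to an expected modest step of a 2.6-fold higher number from compound 1 to compound 3 (0.42 log units; beyond the scatter).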

Compound 3, inhibition constant: 26 nM
The estimate for compound 3 lay 5.2-fold (0.72 log units) below the measured number; measured number above the stated range.
By their numbers in this assay, from the lowest: compound 1; then compounds 2 and 3 (each within the scatter of the next).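

Replacing 4-aminophenyl with phenyl in this assay gives a 14-fold higher number from compound 1 to compound 3 (1.14 log units; beyond the scatter) as a large step. The amino group on the outer six-membered ring therefore counts too, whereas the earlier pair showed only the effect of a methylamino on the shared core. Nothing measured here explains this loss.

Going by these compounds, it remains open whether another group in this place, such as a hydroxyl or an acetamide, would keep the number close to that of compound 1.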